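A few compounds are considered here, and "the series" means these few. Any claim that something is new, unique, unknown or untested is made for them only; others in the source may bear on it.

Measured compounds:
Compound 1, `CC(C)(C)c1ccc(/C=C/C(=O)c2ccc(OCC(=O)N[C@H]3CCOC3=O)cc2)cc1`, gives 17200 nM.
Compound 2, `O=C(CNc1ccccc1F)N[C@H]1CCOC1=O`, gives > 64000 nM, a limit of the assay and not a number.
Compound 3, `O=C(CNc1ccc(Cl)cc1Cl)N[C@H]1CCOC1=O`, gives > 64000 nM, again a limit and not a number.

All three were tested in a functional assay on MGC-803 cells (Homo sapiens) for antiproliferative activity, read by MTT assay, with a stated time of 72 h; a lower number here means a stronger inhibitor, a higher number a weaker inhibitor. Compound 1 is the only one of the three that gives an actual number in this assay, 17200 nM. Compound 2 stands at the limit of this assay, and so does compound 3: the limit of > 64000 nM in this assay, at which 2 of the 3 values shown sit. Nothing more can be said about where compound 2 sits than that it lies at that limit.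

Compound 4, `O=C(CNc1ccccc1)N[C@H]1CCOC1=O`, is the unmeasured partner of compound 2. It differs from compound 2 in one place: hydrogen in place of fluoro on an aromatic carbon. Going by the values given here, no measured pair in this set shows what such a change does, so there is no measured step to lean on. Because compound 2 sits at the limit shown in the limit of > 64000 nM in this assay, at which 2 of the 3 values shown sit, a small change of this kind is not expected to move the value beyond the usual scatter, and compound 4 is expected to remain at or near that limit.

Compound 4 is therefore estimated at 80000 nM in this assay, with a range from 30000 nM to 200000 nM. The estimated step that the limit leaves unreadable from compound 2 to compound 4 amounts to no change beyond the scatter.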

Compound 4, half-maximal inhibitory concentration: > 64000 nM
Compound 4 ended at the assay's limit; the forecaster's own chance of this, stated with the estimate: 75%; the middle value does not contradict the limit.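

Going by these compounds alone, compound 2 and compound 4 each stand at a limit of this assay and not at a number, so no step between them can be read: the limit of > 64000 nM in this assay, at which 3 of the 4 values shown sit.

Left open is how far compound 2 and compound 4 lie past that limit, and which feature of compound 1, the only one with an actual number, sets it apart.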